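The source may report more compounds than this note shows. Statements on the series, on what has been measured and on what is new or still open speak of the compounds shown alone.

Among the measured compounds shown here, compound 1 `Cc1ccc(S(=O)(=O)NCc2cn(C[C@H](O)[C@H]3OC(=O)C(OCc4ccccc4)=C3OCc3ccccc3)nn2)cc1` is the only member of this small set with a number in a functional assay on HCT-116 cells (Homo sapiens) for antiproliferative activity, read by MTT assay, with a stated time of 72 h (on this read-out lower numbers stand for stronger inhibition and higher numbers for weaker inhibition), where compound 1 gives 13100 nM. Compound 2 `O=C1O/C(=C\Cn2cc(-c3cc(F)cc(F)c3)nn2)C(OCc2ccccc2)=C1OCc1ccccc1` reaches only a limit of the assay in this assay, > 100000 nM. Compound 3 `O=C1O/C(=C\Cn2cc(-c3ccc(Br)cc3)nn2)C(OCc2ccccc2)=C1OCc1ccccc1` likewise reaches only a limit in this assay, > 100000 nM. For the measured compounds named here, the one step between measured compounds, a step that the two limits leave unreadable from compound 2 to compound 3, cannot be read because both of its ends sit at the limit of > 100000 nM in this assay, at which 2 of the 3 values shown sit. Compound 4 `COc1ccccc1-c1cn(C[C@H](O)[C@H]2OC(=O)C(OCc3ccccc3)=C2OCc2ccccc2)nn1` has not yet been measured; it differs from compound 1 in one place, (2-methoxyphenyl in place of (((4-methylphenyl)sulfonyl)amino)methyl on an aromatic carbon). Going by the values given here, no measured step shares this change, and compound 2 and compound 3 differ from compound 1 in more than one place, so nothing direct can be carried over. Since compound 2 and compound 3, which also carry an aromatic carbon ring on the five-membered aromatic ring with 3 nitrogen, give only limits, compound 4 is expected to lose ground against compound 1, a step of a 2.7-fold higher number from compound 1 to compound 4 (0.43 log units; beyond the scatter) in this assay. Compound 4 is therefore estimated at 35000 nM, with a range from 9000 nM to 100000 nM.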

Compound 4, half-maximal inhibitory concentration: > 100000 nM
Compound 4: a limit, no number; the forecaster's own chance of this, stated with the estimate: 35%; at least 2.8-fold (0.45 log units) between middle value and limit.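

In this assay, the change at this aromatic carbon alone gives an at least 7.6-fold higher number from compound 1 to compound 4 (0.88 log units; beyond the scatter), with the rest of compound 1 left in place. Compound 2 and compound 3 differ from compound 1 in more than one place and could not tie a loss to this position, whereas this pair shows that the 2-methoxyphenyl group does not keep the activity of the (((4-methylphenyl)sulfonyl)amino)methyl group here. The full size of the step stays unknown, because compound 4 gives only a limit of the assay: the limit of > 100000 nM in this assay, at which 3 of the 4 values shown sit.

The compounds shown leave open which part of the (((4-methylphenyl)sulfonyl)amino)methyl group matters. An aminomethyl or acetamidomethyl group at the same carbon would test whether the activity persists without the 4-methylphenyl ring.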